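The compounds below may be only part of what the source reports. "The series", "measured", "known", "first", "only" and "open" are said of these compounds alone.

Compound 3 `N#Cc1ccc(-c2nc(C(c3ccc(F)cc3)c3ccc(F)cc3)sc2CC(=O)O)cc1` gives 150 nM in an in vitro assay on HEK385-7 cells for displacement of a labelled ligand from prostaglandin D2 receptor 2 (Homo sapiens) (a lower number here means a stronger inhibitor, a higher number a weaker inhibitor), and stands highest of the three measured numbers: compound 2 `O=C(O)Cc1sc(C(c2ccc(F)cc2)c2ccc(F)cc2)nc1-c1cc(F)cc(F)c1` gives 35 nM, and compound 1 `O=C(O)Cc1sc(C(c2ccc(F)cc2)c2ccc(F)cc2)nc1-c1cccc(F)c1` gives 1.4 nM, with a 4.3-fold higher number from compound 2 to compound 3 (0.63 log units; beyond the scatter) and a 110-fold higher number from compound 1 to compound 3 (2.03 log units; beyond the scatter). Compound 4 `N#Cc1cc(-c2nc(C(c3ccc(F)cc3)c3ccc(F)cc3)sc2CC(=O)O)ccc1F` differs from compound 3 by 3-cyano-4-fluorophenyl in place of 4-cyanophenyl on an aromatic carbon. Among the compounds with values here, the one measured step that bears on placing a fluorine on this six-membered aromatic ring is a 25-fold higher number from compound 1 to compound 2 (1.40 log units; beyond the scatter), a large rise in the number. On that basis a further rise in this assay is expected for compound 4, though a smaller step than that one is also possible. Compound 4 is therefore estimated at 450 nM, within 120 nM to 1800 nM, which amounts to an expected 3.0-fold higher number from compound 3 to compound 4 (0.48 log units; beyond the scatter).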

Compound 4, half-maximal inhibitory concentration: 57 nM
The estimate for compound 4 lay 7.9-fold (0.90 log units) above the measured number; measured number below the stated range.
By their numbers in this assay, from the lowest: compound 1; then compounds 2 and 4 (each within the scatter of the next); then compound 3.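

In this assay the exchange of 4-cyanophenyl for 3-cyano-4-fluorophenyl lowers the number (a 2.6-fold lower number from compound 3 to compound 4 (0.42 log units; beyond the scatter)), so a fluorine on this ring need not raise it as it did in the earlier step (a 25-fold higher number from compound 1 to compound 2 (1.40 log units; beyond the scatter)). The nitrile also changes place in this exchange, so the share of the fluorine cannot be separated from that of the nitrile. 3-Cyano-4-fluorophenyl cannot be told apart from 3,5-difluorophenyl (a 1.6-fold higher number from compound 2 to compound 4 (0.21 log units; within the scatter)), while 3-fluorophenyl keeps a large lead (a 41-fold higher number from compound 1 to compound 4 (1.61 log units; beyond the scatter)). On these data alone, how 3-cyanophenyl alone, or a ring bearing an amine or a methoxy group, would read here remains open. No measurement shown explains why these numbers shift.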